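The source may hold more compounds than are shown below. What is called first, only, known or untested is meant among the compounds shown, and "the series" means these compounds.

Compound 3 `N#CC1=C(NC(=S)Nc2ccc(Cl)cc2)N(c2ccc(S(N)(=O)=O)cc2)C2=C(C(=O)CCC2)C1c1ccc(Cl)cc1Cl` is one of three compounds tested in a functional assay on Ehrlich cells (Mus musculus) for cytotoxicity, read by trypan blue exclusion, with a stated time of 2 h, tested at 10 ug/mL; a lower number here means a weaker effect, a higher number a stronger effect of the compound at the concentration tested. In this assay compound 3 gives 30%, the second highest of the three numbers. Its nearest neighbour is compound 1 `N#CC1=C(N)N(c2ccc(S(N)(=O)=O)cc2)C2=C(C(=O)CCC2)C1c1ccc(Cl)cc1Cl`, which in this assay gives 40%; the step of a number 10 percentage points lower from compound 1 to compound 3 (within the scatter), so the two cannot be told apart. The furthest is compound 2 `C=CCNC(=S)NC1=C(C#N)C(c2ccc(Cl)cc2Cl)C2=C(CCCC2=O)N1c1ccc(S(N)(=O)=O)cc1`, which in this assay gives 10%; here the step of a number 20 percentage points higher from compound 2 to compound 3 (beyond the scatter).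

Compound 4 `N#CC1=C(NS(=O)(=O)c2ccc(Br)cc2)N(c2ccc(S(N)(=O)=O)cc2)C2=C(C(=O)CCC2)C1c1ccc(Cl)cc1Cl` has not been measured yet. Compared with compound 3 the change is a group of 10 heavy atoms (6 carbon, 2 oxygen, 1 sulfur, 1 bromine; one six-membered aromatic ring of carbon only) in place of a group of 10 heavy atoms (7 carbon, 1 nitrogen, 1 sulfur, 1 chlorine; one six-membered aromatic ring of carbon only), on an amine nitrogen. The measured steps that touch the same amine nitrogen are the ones from compound 1: adding the allyl-bearing group gave a number 30 percentage points lower from compound 1 to compound 2 (beyond the scatter), while adding the 4-chlorophenyl-bearing group gave a number 10 percentage points lower from compound 1 to compound 3 (within the scatter). So attachments at this nitrogen have so far either left the number where it was or lowered it, and none of them carried a sulfonyl or a bromine, so the present change has no direct precedent. Compound 4 is therefore expected to land close to compound 3, with the step of no change at the digits printed from compound 3 to compound 4 (within the scatter) estimated to lie within the scatter. The estimate for compound 4 is 30%, expected to fall between 10% and 50%.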

Compound 4, a percentage reported as activity, at one concentration (the size of the read-out at that concentration, not a potency): 90%
Compound 4: middle estimate off by 60 percentage points, on the low side, outside the stated range (above it).
By their numbers in this assay, from the lowest: compound 2; then compounds 3 and 1 (each within the scatter of the next); then compound 4.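

Until now, attachments at this amine nitrogen had only lowered the number in this assay or left it within the scatter, so the position seemed to offer nothing to gain; (4-bromophenyl)sulfonyl in place of hydrogen overturns that picture, with a number 50 percentage points higher from compound 1 to compound 4 (beyond the scatter). The position also proves sensitive to the nature of the attached group and not just to its size or to the presence of an aromatic ring: with the same number of heavy atoms and one such ring on each side of the change, the swap gives a number 60 percentage points higher from compound 3 to compound 4 (beyond the scatter), and the gap to the allyl-bearing compound is wider, with a number 80 percentage points higher from compound 2 to compound 4 (beyond the scatter). No measurement shown here explains why this group stands so far apart from the others.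

On these data alone, the sulfonyl and the bromine enter in the same step, so the share of each in the rise stays open, and (4-chlorophenyl)sulfonyl or plain phenylsulfonyl at this nitrogen would help to separate them. As far as these compounds go, whether the ring is needed at all also stays open, a question that methylsulfonyl at the same place would address.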